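The source may report more compounds than this note shows. Statements on the series, on what has been measured and on what is new or still open speak of the compounds shown alone.

Measured so far, in a functional assay on MCF7 cells (Homo sapiens) for inhibition, read by sulforhodamine B assay; a higher number here means a weaker inhibitor, a lower number a stronger inhibitor: compound 1 `CCCc1ccc(NC2=CC(=O)c3nc4n(c3C2=O)[C@H]2OC[C@@H](O)[C@H]2OC4)cc1` gives 4660 nM. Compound 2 `O=C1C(NC2CCCC2)=CC(=O)c2c1nc1n2[C@H]2OC[C@@H](O)[C@H]2OC1` gives only a limit of the assay, > 16000 nM. Compound 3 `O=C1C(N2CCCC2)=CC(=O)c2c1nc1n2[C@H]2OC[C@@H](O)[C@H]2OC1` likewise gives only a limit, > 16000 nM.

Going by the values given here, compound 1 thus stands as the only numbered value among the three; the other two sit at a limit, as the limit of > 16000 nM in this assay, at which 2 of the 3 values shown sit, records. Among the compounds with values here, the single measured step, a step that the two limits leave unreadable from compound 2 to compound 3, is unreadable and concerns a different place on the core.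

Compound 4 `CCOc1ccccc1NC1=CC(=O)c2nc3n(c2C1=O)[C@H]1OC[C@@H](O)[C@H]1OC3` differs from compound 1 by 2-ethoxyphenyl in place of 4-propylphenyl on an amine nitrogen. Within the data shown here, no measured step bears on an exchange at the amine nitrogen, so no direction can be read from the data, and no step beyond the usual scatter is expected: a 1.0-fold higher number from compound 1 to compound 4 (0.00 log units; within the scatter) is the expected step. Compound 4 is therefore estimated at 4700 nM, between 1500 nM and 15000 nM.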

Compound 4, half-maximal inhibitory concentration: > 4000 nM
Compound 4: only a limit was reported; the forecaster's own chance of this, stated with the estimate: 15%; the middle value does not contradict the limit.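

In this assay, going by these compounds alone, compound 4 gives only a limit, > 4000 nM, so no new step from compound 1 to compound 4 can be read. The compounds shown leave open how large the effect of exchanging 4-propylphenyl for 2-ethoxyphenyl on the amine nitrogen is, and in which direction it runs.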